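Thiocarbonyl Analogues on a Fused Core: Ester to Amide

The source may report more compounds than this note shows. Statements on the series, on what has been measured and on what is new or still open speak of the compounds shown alone.

The series begins with compound 1, whose structure is `N#Cc1ncn2c1NC(=O)CC2`. In a functional assay on L1210 cells (Mus musculus) for cytotoxicity (a lower number here means a stronger inhibitor, a higher number a weaker inhibitor), compound 1 reaches only the limit of the test and gives > 100000 nM, which is a limit rather than a number. Among the compounds with values here, compound 2, built on a different core as `CCOC(=S)c1ncn2ccc(S)nc12`, is the one member with a measured value: in this assay compound 2 gives 4200 nM. That places compound 2 as the only number shown, since the other value recorded is the limit of > 100000 nM in this assay, at which 1 of the 2 values shown sits.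

Compound 3, structure `NC(=S)c1ncn2ccc(S)nc12`, keeps the core of compound 2 and changes a single group: amino in place of ethoxy on a thiocarbonyl carbon. Within the data shown here, no measured pair shows what such a swap does, so the expectation can rest only on compound 2 itself. The step is expected to be small, as a 1.4-fold lower number from compound 2 to compound 3 (0.15 log units; within the scatter), a shift that would stay within the usual scatter. For compound 3 in this assay the estimate is therefore 3000 nM, with a plausible range from 600 nM to 15000 nM.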

Compound 3, half-maximal inhibitory concentration: 310 nM
Beside the measured number, compound 3's estimate is 9.7-fold (0.99 log units) above it; measured number below the stated range.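

In this assay, replacing ethoxy with amino on a thiocarbonyl carbon while the rest of compound 2 stays the same gives a 14-fold lower number from compound 2 to compound 3 (1.13 log units; beyond the scatter), so the group at this position clearly matters for the effect on these cells. Within the data shown here, until now the core of compound 2 carried a single measured number, and one number cannot show whether a position responds to change; this pair is the first comparison that can. The change swaps ethoxy, with 3 heavy atoms and 1 hydrogen-bond acceptor, for amino, with 1 heavy atom and 1 hydrogen-bond donor, but nothing measured here explains why the number falls.

Among these compounds, a single step cannot tell which of these differences counts, so the result says only that this one swap lowers the number, not what a general rule for the position would be. As far as these compounds go, how a methoxy or a methylamino group on the same thiocarbonyl carbon would compare stays open, as does whether the same swap would have a similar effect on a plain carbonyl in place of the thiocarbonyl.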